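From 4-chlorophenyl to 2-chlorobenzyl on an amide-type nitrogen

This account rests on a few compounds, and the source may have more. Where it says the series, first, only, none or still open, it means among the compounds named here.

Among the measured compounds shown here, in an ADME assay on BHK-21 cells (Mesocricetus auratus) for cytotoxicity, with a stated time of 3 days (on this read-out lower numbers stand for higher toxicity in this test and higher numbers for lower toxicity in this test), compound 1 (`O=C(CCSc1nnc(-c2ccncc2)s1)Nc1ccc(Cl)cc1`) gives 8210 nM, the only number so far. Compound 2 (`CC(Sc1nnc(-c2ccncc2)s1)C(=O)NCc1ccc(Cl)cc1`) is recorded as "not determined" (no result reported), so compound 1 has no measured neighbour to stand against. Compound 3 (`O=C(CCSc1nnc(-c2ccncc2)s1)NCc1ccccc1Cl`) carries 2-chlorobenzyl in place of 4-chlorophenyl on an amide-type nitrogen, and the rest of the structure stays as in compound 1. For the measured compounds named here, no step between measured compounds is available to size such a change in this assay, so the expectation rests on compound 1 alone at 8210 nM. A shift no larger than the usual scatter is expected, with a slight lean towards lower toxicity in this test. The estimated step is a 1.2-fold higher number from compound 1 to compound 3 (0.09 log units; within the scatter). The expected value for compound 3 is 10000 nM, with an estimated range from 3500 nM to 30000 nM.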

Compound 3, half-maximal cytotoxic concentration: > 50000 nM
Compound 3 was reported as a limit (the forecaster's own chance of this, stated with the estimate: 20%); middle value at least 5.0-fold (0.69 log units) from the limit.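

In this assay, among the compounds shown here, the swap to 2-chlorobenzyl on the amide-type nitrogen gives an at least 6.0-fold higher number from compound 1 to compound 3 (0.78 log units; beyond the scatter), the first step that can be sized. This position is therefore not silent: with the rest of the structure unchanged, the group on this nitrogen alone moves the read-out towards lower toxicity in this test. Going by these compounds, the full size of the step stays open, since compound 3 is given only as a limit of the assay: the limit of > 50000 nM in this assay, at which 1 of the 3 values shown sits.

Whether the shift follows the benzyl form or the 2-chloro pattern remains unresolved; 4-chlorobenzyl or plain benzyl on the same nitrogen, with the rest of compound 1 kept, would separate the two. Also open, on these data alone, is how this read-out responds to an amine on the benzyl ring, such as 2-aminobenzyl.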